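The source may report more compounds than this note shows. Statements on the series, on what has been measured and on what is new or still open speak of the compounds shown alone.

In an ADME assay on cells (spleen, Mus musculus, strain C57BL/6) for inhibition, read by flow cytometry and propidium iodide staining, with a stated time of 24 h, at 37 degrees C (on this read-out lower numbers stand for an effect already at smaller amounts and higher numbers for an effect only at larger amounts of compound), two compounds have been measured so far. Compound 1 (`O=C(Cn1cc(CO)nn1)NCc1ccccc1`) gives 490 uM and compound 2 (`O=C(O)CCCCc1cn(CC(=O)NCc2ccccc2)nn1`) gives 1080 uM as the higher of the two numbers. Compound 3 (`Cc1ccc(-c2cn(CC(=O)NCc3ccccc3)nn2)cc1`) is the next to be considered, and it differs from compound 2 in one place (4-methylphenyl in place of 4-carboxybutyl on an aromatic carbon): 4-methylphenyl stands in place of 4-carboxybutyl on an aromatic carbon of the five-membered aromatic ring with 3 nitrogen.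

Within the data shown here, only one measured step bears on this change, a 2.2-fold higher number from compound 1 to compound 2 (0.34 log units; beyond the scatter) when 3-carboxypropyl took the place of hydroxy on a saturated chain carbon bound to an aromatic carbon, and it was modest. Compound 2 stands at 1080 uM with its 4-carboxybutyl chain and compound 3 gives that chain up, so a move of similar modest size toward a lower number is expected. Among the measured compounds shown here, the expected step in this assay is a 2.7-fold lower number from compound 2 to compound 3 (0.43 log units; beyond the scatter) and it rests on a single comparison, since no measured compound has an aromatic group at this place. The estimate for compound 3 is 400 uM with 120 uM to 1100 uM as the expected range.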

Compound 3, concentration for half-maximal effect: "non-toxic" (no number reported)
Compound 3: no number reported, so the estimate cannot be set against anything.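

In this assay, among these compounds, compound 3 is recorded only as "non-toxic", with no number, so no step from compound 2 to compound 3 can be read. Nothing measured here offers an explanation for this result. The compounds shown leave open how far 4-methylphenyl in place of 4-carboxybutyl moves the number on this read-out.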